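Lengthening the Amine Chain from Compound 3 to Compound 4

The source may hold more compounds than are shown below. What is called first, only, known or untested is meant among the compounds shown, and "the series" means these compounds.

Compound 1 `CCN(CC)CCCn1c(N)c(-c2nc3ccccc3n2C)c2nc(C#N)c(C#N)nc21`: 7240 nM
Compound 2 `CN(C)CCn1c(N)c(-c2nc3cc(Cl)ccc3[nH]2)c2nc(C#N)c(C#N)nc21`: > 50000 nM (a limit)
Compound 3 `CCN(CC)CCn1c(N)c(-c2nc3cc(Cl)ccc3[nH]2)c2nc(C#N)c(C#N)nc21`: > 50000 nM (a limit)

In an ADME assay on HEK293 cells (Homo sapiens) for cytotoxicity, read by MTT assay, with a stated time of 48 h (on this read-out higher numbers stand for weaker inhibition and lower numbers for stronger inhibition), compound 3 gives > 50000 nM, which is a limit and not a number, and this is the limit of > 50000 nM in this assay, at which 2 of the 3 values shown sit. Compound 4 `CCN(CC)CCCn1c(N)c(-c2nc3cc(Cl)ccc3[nH]2)c2nc(C#N)c(C#N)nc21` carries 3-(diethylamino)propyl where compound 3 carries 2-(diethylamino)ethyl: (diethylamino)methyl in place of diethylamino on a saturated chain carbon, two bonds along the chain from an aromatic nitrogen. The nearest measured change is a step that the two limits leave unreadable from compound 2 to compound 3, so it offers no size to carry over. Compound 1 also carries 3-(diethylamino)propyl and gives 7240 nM, although it differs elsewhere too. A move towards stronger inhibition in this assay is therefore expected, with low confidence. The expected step is an at least 2.5-fold lower number from compound 3 to compound 4 (0.39 log units; beyond the scatter). For compound 4 the estimate is 20000 nM, with an expected range of 6000 nM to 50000 nM.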

Compound 4, half-maximal inhibitory concentration: 8420 nM
Compound 4: middle estimate off by 2.4-fold (0.38 log units), on the high side; measured number inside the range.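

In this assay, the longer 3-(diethylamino)propyl chain gives a readable number where the shorter chains did not, with an at least 5.9-fold lower number from compound 3 to compound 4 (0.77 log units; beyond the scatter) and an at least 5.9-fold lower number from compound 2 to compound 4 (0.77 log units; beyond the scatter). With that longer chain, the two benzimidazole groups cannot be told apart, with a 1.2-fold higher number from compound 1 to compound 4 (0.07 log units; within the scatter). Compound 2 and compound 3 each stand at a limit and not at a number, so the full size of both steps stays unknown: the limit of > 50000 nM in this assay, at which 2 of the 4 values shown sit.

On these data alone, whether a still longer chain, such as 4-(diethylamino)butyl, would lower the number further stays open. So does the effect of a piperidine in place of diethylamino.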